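Trypsin Inhibition in This Assay: From Compound 1 to Compound 4

A few compounds are considered here, and "the series" means these few. Any claim that something is new, unique, unknown or untested is made for them only; others in the source may bear on it.

Measured compounds:
- compound 1, `C[C@](NC(=O)[C@H](CCCCN)NC(=O)[C@H](CCCNC(=N)N)NC(=O)c1ccccc1)(C(N)=O)c1ccccc1`: 11.8%
- compound 2, `CN(C(=O)[C@H](CCCNC(=N)N)NC(=O)c1ccccc1)[C@@H](CCCCN)C(=O)N[C@@H](C(N)=O)c1ccccc1`: <= 5%
- compound 3, `N=C(N)NCCC[C@H](NC(=O)C(=O)c1ccccc1)C(=O)N[C@@H](CCCCN)C(=O)N[C@@H](C(N)=O)c1ccccc1`: 33.5%

Of the compounds shown here, three of a shared core have been tested in an assay on isolated protein for inhibition of Trypsin (Homo sapiens), read by fluorescence, with a stated time of 15 min, tested at 50 uM; on this read-out lower numbers stand for less inhibition and higher numbers for more inhibition at the one concentration tested (going by the name of the read-out). Compound 1, `C[C@](NC(=O)[C@H](CCCCN)NC(=O)[C@H](CCCNC(=N)N)NC(=O)c1ccccc1)(C(N)=O)c1ccccc1`, gives 11.8%. Compound 3, `N=C(N)NCCC[C@H](NC(=O)C(=O)c1ccccc1)C(=O)N[C@@H](CCCCN)C(=O)N[C@@H](C(N)=O)c1ccccc1`, gives 33.5% in this assay. Among the two numbers reported, compound 1 stands lowest, and the nearest number, that of compound 3, lies higher by a gap beyond the scatter. Compound 2, `CN(C(=O)[C@H](CCCNC(=N)N)NC(=O)c1ccccc1)[C@@H](CCCCN)C(=O)N[C@@H](C(N)=O)c1ccccc1`, reaches only a limit of this assay, <= 5%; (the limit of <= 5% in this assay, at which 1 of the 3 values shown sits). No two of these compounds differ in a single place, so no measured step can be drawn from them.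

Compound 4, `N=C(N)NCCC[C@H](NC(=O)c1ccccc1)C(=O)N[C@@H](CCCCN)C(=O)N(CC(N)=O)c1ccccc1`, is not yet measured. It differs from compound 1 in one place: (carbamoylmethyl)(phenyl)amino in place of (1-carbamoyl-1-phenylethyl)amino on a carbonyl carbon. Going by the values given here, since no measured step is available to guide the estimate, the expectation rests on compound 1 alone and its 11.8%. The step from compound 1 to compound 4 in this assay is expected to be small, with no change beyond the scatter, and in either direction. Compound 4 is therefore estimated at 10%, within a range from 0% to 28%, with the expected step of a number 1.8 percentage points lower from compound 1 to compound 4 (within the scatter).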

Compound 4, a percentage reported as inhibition, at one concentration (the size of the read-out at that concentration, not a potency): <= 5%
Compound 4 ended at the assay's limit; the forecaster's own chance of this, stated with the estimate: 35%; middle value at least 5 percentage points from the limit.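

In this assay compound 4 gives <= 5%, which is a limit of the assay and not a number. Going by these compounds alone, this is the first step that can be read at this place, on a carbonyl carbon whose other neighbour is a saturated chain carbon, and it comes out as a number at least 6.8 percentage points lower from compound 1 to compound 4 (that floor lies within the scatter); exchanging (1-carbamoyl-1-phenylethyl)amino for (carbamoylmethyl)(phenyl)amino therefore brings no gain in inhibition, while any loss cannot be told apart from the scatter at its floor. The change also leaves no room for a finer reading, as the result falls at the low end of the read-out, where another compound of the series already sits: the limit of <= 5% in this assay, at which 2 of the 4 values shown sit.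

From the compounds shown here alone, the true size of the step stays open, since only its floor is known, and a compound at the limit cannot show whether the change costs a little or a lot. Also open, going by these compounds, is what this place would give with a carboxylic acid in place of the carbamoyl group, or with a longer chain carrying the carbamoyl group on the same nitrogen.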